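Working notes: 4-methoxyphenyl in place of 3-nitrophenyl

The source may hold more compounds than are shown below. What is called first, only, known or untested is meant among the compounds shown, and "the series" means these compounds.

Measured in a functional assay on HCT-116 cells (Homo sapiens) for inhibition, read by MTT assay, with a stated time of 2 days; on this read-out lower numbers stand for higher toxicity in this test and higher numbers for lower toxicity in this test:
- compound 1 `Nc1ccccc1NC(=O)CCCNCC(=O)Nc1ccc(Br)cc1` gives > 100000 nM (a limit)
- compound 2 `Nc1ccccc1NC(=O)c1ccc(NCC(=O)Nc2cccc([N+](=O)[O-])c2)cc1` gives > 100000 nM (a limit)

In this assay compound 2 stands at > 100000 nM, which is a limit of the assay and not a number. Within the data shown here, the series so far sits at the limit of > 100000 nM in this assay, at which 2 of the 2 values shown sit, so no step between measured compounds can be given. Compound 3 `COc1ccc(NC(=O)CNc2ccc(C(=O)Nc3ccccc3N)cc2)cc1` has 4-methoxyphenyl in place of 3-nitrophenyl on an amide-type nitrogen and otherwise keeps the core of compound 2. No change beyond the scatter is expected in this assay, and a report as a limit again is quite likely. The expected move, a number no higher from compound 2 to compound 3 (the limit leaves the size open), is an estimate that rests only on the limit held by compound 2. For compound 3 the estimated value is 100000 nM, with an expected range from 30000 nM to 300000 nM.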

Compound 3, concentration lethal to 50% of the cells: > 100000 nM
Compound 3 ended at the assay's limit; the forecaster's own chance of this, stated with the estimate: 75%; the middle value sits exactly at the limit.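

Compound 2 and compound 3 both stand at a limit of this assay and not at a number, so no step between them can be read: the limit of > 100000 nM in this assay, at which 3 of the 3 values shown sit.

The compounds shown leave open which change, if any, would bring a value within the readable range of this assay in this series.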